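The source may report more compounds than this note shows. Statements on the series, on what has been measured and on what is new or still open speak of the compounds shown alone.

Measured compounds:
compound 1 `Cc1ncc(CO)c(-c2nc3ccccn3c2NC2CCCCC2)c1OCc1ccccc1` — "not active" (no number reported)
compound 2 `Cc1ncc(CO)c2c(Nc3ccccc3)c(NCc3ccccc3)oc12` — 1680 nM
compound 3 `CCOC(=O)CNc1oc2c(C)ncc(CO)c2c1Nc1ccccn1` — "not active" (no number reported)

In a functional assay on HEK293 cells for agonist activity at Toll-like receptor 8 (Homo sapiens), read by reporter gene assay (a higher number here means that more compound is needed for the effect, a lower number that less compound is needed), compound 2 is the only one of the three with a number, 1680 nM. Compound 3 stands with compound 1 among the entries that gave no number; in this assay compound 3 is recorded as "not active" (no number reported), and nothing places it on the scale relative to compound 2.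

Compound 4 `Cc1ncc(CO)c2c(Nc3ccccn3)c(N)oc12` differs from compound 3 by hydrogen in place of (ethoxycarbonyl)methyl on a nitrogen on an aromatic ring. For the measured compounds named here, no measured pair in the set shows this change, so the size and direction of the step in this assay cannot be taken from the data. Given that compound 3 gave "not active" (no number reported), compound 4 is expected to remain weak, with a fair chance of again giving no number. The estimate for compound 4 in this assay is 6000 nM, within 1000 nM to 40000 nM.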

Compound 4, half-maximal effective concentration: "not active" (no number reported)
For compound 4 the study gives words and no number; no gap can be computed for the estimate.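

In this assay compound 3 gives "not active" (no number reported) and compound 4 gives "not active" (no number reported), so no step can be read between them, and no evidence bears on this result. The compounds shown leave open what exchanging (ethoxycarbonyl)methyl for hydrogen does on a scale with numbers.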